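Cytotoxicity of an aryl thioether analogue in the series

A few compounds are considered here, and "the series" means these few. Any claim that something is new, unique, unknown or untested is made for them only; others in the source may bear on it.

Compound 2 `Cc1cc(N2CCCC2)c2ncc(CSCCc3ccccc3)n2c1` and compound 4 `Cc1cc(Sc2ccc(Cl)cc2)c2ncc(CSCCc3ccccc3)n2c1` share a core; the difference between them is (4-chlorophenyl)sulfanyl in place of pyrrolidin-1-yl on an aromatic carbon. In an ADME assay on HEL cells (Homo sapiens) for cytotoxicity, with a stated time of 3 days (a lower number here means that less compound is tolerated, a higher number that more compound is tolerated), compound 2 stands only at a limit, > 100 ug/mL, so its true value is not known. Among the measured compounds shown here, compound 1 `Cc1cc(-c2ccc(C=O)cc2)cn2c(CSCCc3ccccc3)cnc12` is the only member of the set with a plain number in this assay, where compound 1 gives 100 ug/mL. Compound 3 `Cc1cc(N2CCCC2)c2ncc(CSCc3ccccc3)n2c1` also stands at a limit in this assay, >= 20 ug/mL. For the measured compounds named here, the step that the two limits leave unreadable from compound 2 to compound 3 is therefore not readable, and no measured step in the set touches the position changed in compound 4, so there is no direct guide to the size or direction of the step to compound 4. Two of the three values sit at limits, the limit of > 100 ug/mL in this assay, at which 1 of the 3 values shown sits, and (the limit of >= 20 ug/mL in this assay, at which 1 of the 3 values shown sits), so the series as a whole is tolerated up to the top of the tested range or close to it. Compound 4 is expected to fall near the upper end of the tested range in this assay, with an estimate of 100 ug/mL spanning 20 ug/mL to 200 ug/mL. The expected step of a number no higher from compound 2 to compound 4 (the limit leaves the size open) is estimated not to exceed the scatter, though a limit is about as likely as a number.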

Compound 4, minimum cytotoxic concentration: 4 ug/mL
Compound 4: middle estimate off by 25-fold (1.40 log units), on the high side; measured number outside the range, below it.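

Working notes on the aromatic carbon ortho to a fused ring: in this assay, (4-chlorophenyl)sulfanyl in place of pyrrolidin-1-yl gives an at least 25-fold lower number from compound 2 to compound 4 (1.39 log units; beyond the scatter), the only step in the set that can be read, since the limits leave the remaining step unreadable. Among the compounds shown here, this is the first evidence that this position can strongly change the concentration tolerated, and that the series is not uniformly tolerated near the top of the tested range. The values at hand show the size of this change but offer nothing that accounts for it.

The change replaces the whole substituent at once, so the compounds shown do not separate the contributions of the sulfur link, the aromatic ring and the chlorine; phenylsulfanyl, 4-chlorophenyl joined directly to the same carbon, or a piperidin-1-yl group there would divide these parts. On these data alone, it also remains open whether (4-chlorophenyl)sulfanyl has the same effect when the chain of compound 3 replaces that of compound 4, and whether other substituents at this carbon stay as well tolerated as pyrrolidin-1-yl.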